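From Benzyl to 4-Methoxyphenyl on a Ring Nitrogen

The source may hold more compounds than are shown below. What is called first, only, known or untested is meant among the compounds shown, and "the series" means these compounds.

In a functional assay on T47D cells (Homo sapiens) for antiproliferative activity, read by MTT assay, with a stated time of 72 h (a lower number here means a stronger inhibitor, a higher number a weaker inhibitor), compound 1 (`COc1cc(-c2nccn2Cc2ccccc2)cc(OC)c1OC`) reads > 100000 nM. That figure is a limit of the assay and not a measured number, so compound 1 can only be placed at the weak end of the scale. Compound 2 (`COc1cc(-c2nccn2-c2ccc3cc[nH]c3c2)cc(OC)c1OC`), which carries a different group on the same nitrogen, gives a true number of 18000 nM.

Compound 3 (`COc1ccc(-n2ccnc2-c2cc(OC)c(OC)c(OC)c2)cc1`) has 4-methoxyphenyl in place of benzyl on an aromatic nitrogen. With only compound 2 at 18000 nM as a numeric guide, a gain in strength beyond the scatter seems likely. The expected change in this assay is estimated as an at least 20-fold lower number from compound 1 to compound 3 (1.30 log units; beyond the scatter). Compound 3 is expected to give about 5000 nM, with an estimated range from 300 nM to 60000 nM.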

Compound 3, half-maximal inhibitory concentration: 1400 nM
Estimate against measurement, compound 3: 3.6-fold (0.55 log units) above, within the range that was stated.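

Swapping benzyl for 4-methoxyphenyl on this aromatic nitrogen gives an at least 71-fold lower number from compound 1 to compound 3 (1.85 log units; beyond the scatter) in this assay, so this one position can move the core from the weak end of the scale to a true number. Both groups hold one six-membered aromatic ring of carbon only, so that ring alone does not set the result. The value of compound 1 is a limit, and the step is therefore a minimum because compound 1 sits at the edge of the scale: the limit of > 100000 nM in this assay, at which 1 of the 3 values shown sits.

On these data alone, how a plain phenyl or a 4-methoxybenzyl group would read on this nitrogen remains open, so the methoxy group's share of the step cannot be separated from the rest of the change. Also open, as far as these compounds go, is whether an amine on the phenyl ring, as in 4-aminophenyl, would read like the methoxy group.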